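This account rests on a few compounds, and the source may have more. Where it says the series, first, only, none or still open, it means among the compounds named here.

Measured in an assay on HEK293 cells for agonist activity at Toll-like receptor 8 (Homo sapiens), read by reporter gene assay; on this read-out lower numbers stand for an effect already at smaller amounts and higher numbers for an effect only at larger amounts of compound:
compound 1 `CCCCCn1c(N)nc2c(OC)cccc21` gives 3740 nM
compound 2 `CCCCCn1c(N)nc2c(C(F)(F)F)cccc21` gives "not active" (no number reported)
compound 3 `CCCCCn1c(N)nc2c(N(C)C)cccc21` gives 7120 nM

All three share one core and differ only in the group on an aromatic carbon of the fused ring. Compound 3 carries a dimethylamino group there and has the highest of the two reported numbers; its nearest neighbour is compound 1, and the gap a 1.9-fold higher number from compound 1 to compound 3 (0.28 log units; within the scatter) lies within the usual scatter. Compound 2, with trifluoromethyl at the same carbon, showed no activity in this assay, so no number exists for it.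

Compound 4 `CCCCCn1c(N)nc2c(-c3ccccc3)cccc21` has not yet been measured. It differs from compound 3 by phenyl in place of dimethylamino on an aromatic carbon. Going by the values given here, no measured step covers this exact change. Among the compounds with values here, the one step that exists, from methoxy to dimethylamino, stayed within the scatter, while the trifluoromethyl analogue lost activity entirely, and the phenyl group adds a ring where neither of those groups had one. The outcome in this assay is therefore uncertain, with a real chance that compound 4 also shows no activity. If a number is obtained, the step expected is a 1.7-fold higher number from compound 3 to compound 4 (0.23 log units; within the scatter). The estimate for compound 4 is 12000 nM, within a range from 2500 nM to 60000 nM.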

Compound 4, half-maximal effective concentration: "not active" (no number reported)
Nothing numeric was reported for compound 4; there is nothing to compare the estimate with.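

In this assay, going by these compounds alone, compound 4, like compound 2, showed no activity, so no step from compound 3 to compound 4 can be read. Nothing measured here accounts for this result. The compounds shown leave open whether any group carrying a ring at this aromatic carbon can give a measurable number on this read-out.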